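One more methyl: from compound 3 to compound 4

The source may report more compounds than this note shows. Statements on the series, on what has been measured and on what is new or still open speak of the compounds shown alone.

In a functional assay on HL-60 cells (Homo sapiens) for antiproliferative activity, read by MTT assay, with a stated time of 72 h (a lower number here means a stronger inhibitor, a higher number a weaker inhibitor), compound 3 (`COc1cc(C(=O)c2sc3ccccc3c2Nc2ccc(C)cc2)cc(OC)c1OC`) gives 4600 nM as its reading. That lies within the scatter of compound 2 (`COc1cc(C(=O)c2sc3ccccc3c2Nc2ccccc2)cc(OC)c1OC`) at 5200 nM on the same scale. Compound 1 (`COc1cc(C(=O)c2sc3ccccc3c2-c2ccccc2)cc(OC)c1OC`) reads 1700 nM and is the strongest of the three, as the steps (a 3.1-fold higher number from compound 1 to compound 2 (0.49 log units; beyond the scatter)) and (a 2.7-fold higher number from compound 1 to compound 3 (0.43 log units; beyond the scatter)) show.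

Compound 4 (`COc1cc(C(=O)c2sc3cc(C)ccc3c2Nc2ccc(C)cc2)cc(OC)c1OC`) keeps everything in compound 3 except one exchange (methyl in place of hydrogen on an aromatic carbon), a methyl in place of hydrogen on an aromatic carbon. Going by the values given here, the only measured exchange of this kind is the step (a 1.1-fold lower number from compound 2 to compound 3 (0.05 log units; within the scatter)), which stays within the scatter. Among the compounds with values here, it sits in the (4-methylphenyl)amino group, however, so it is only an indirect guide, and no measured compound carries a methyl at the new place. The two steps from compound 1 concern a different exchange. No change beyond the scatter is therefore expected, and the estimated step is small (a 1.2-fold lower number from compound 3 to compound 4 (0.06 log units; within the scatter)) in either direction. Compound 4 is expected near 4000 nM in this assay, with an estimated range from 1500 nM to 10000 nM for the measurement.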

Compound 4, half-maximal inhibitory concentration: 1900 nM
Estimate against measurement, compound 4: 2.1-fold (0.32 log units) above; the measured number falls inside the stated range.
By their numbers in this assay, from the lowest: compounds 1 and 4 (each within the scatter of the next); then compounds 3 and 2 (each within the scatter of the next).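

In this assay, placing a methyl on an aromatic carbon of the six-membered ring of the fused system gives a modest step beyond the scatter (a 2.4-fold lower number from compound 3 to compound 4 (0.38 log units; beyond the scatter)). The same exchange on the (4-methylphenyl)amino group stays within the scatter (a 1.1-fold lower number from compound 2 to compound 3 (0.05 log units; within the scatter)), so among these compounds a methyl in place of hydrogen does not read the same at the two places. No measurement shown here accounts for this difference.

The compounds shown leave open whether a methoxy group, a chlorine atom or an ethyl group at this place would give a step of similar size. They also leave open whether the same methyl would shift the number in the same way in compound 1 or compound 2, both of which carry hydrogen there.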